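Trimming a Chain on the Core of Compound 1

A few compounds are considered here, and "the series" means these few. Any claim that something is new, unique, unknown or untested is made for them only; others in the source may bear on it.

Measured so far:
- compound 1 `CCc1cc(C)cc2nc(N3CCN(C)CC3)oc12`: 0.26
- compound 2 `COc1cc(Cl)cc2nc(N3CCN(C)CC3)oc12`: 0.62

The read-out is an assay on ileum (strain Hartley) with 5-hydroxytryptamine receptor 3A (Cavia porcellus) as the target; on this read-out higher numbers stand for larger maximal responses and lower numbers for smaller maximal responses. Of the two numbers shown, compound 1 stands lowest; compound 2 sits above it by a gap beyond the scatter. Since the two compounds differ in more than one place, their two values show only that gap and nothing about any single change.

Compound 3 `Cc1cc(C)c2oc(N3CCN(C)CC3)nc2c1` has not yet been measured. It differs from compound 1 in one place: hydrogen in place of methyl on a saturated chain carbon bound to an aromatic carbon. Among the compounds with values here, no measured pair shows what such a change does here, so nothing firmer than a guess is available. Because compound 1 gives 0.26, the expected step a number 0.040 higher from compound 1 to compound 3 (within the scatter) is small, in either direction or none beyond the scatter. Compound 3 is estimated at 0.3, within a range from 0.15 to 0.5.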

Compound 3, intrinsic activity: the largest response reached, as a fraction of the reference agonist's: 0.62
Estimate against measurement, compound 3: 0.32 below, and the stated range ends below it.
By their numbers in this assay, from the lowest: compound 1; then compounds 2 and 3 (each within the scatter of the next).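

Trimming ethyl to methyl on a saturated chain carbon bound to an aromatic carbon, with the rest of the core of compound 1 unchanged, gives a number 0.36 higher from compound 1 to compound 3 (beyond the scatter) in this assay. Within the data shown here, this is the first pair here that differs in one place only, so it is the first direct sign that this position matters: removing a single carbon from the chain is enough to shift the maximal response by more than the scatter. No measurement shown bears on why the shorter chain goes with the larger response.

Two groups at one position give only two points, not a trend. Going by these compounds, it remains open how the maximal response would change with a longer chain such as propyl, or with a different kind of group such as an amine, at this place.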